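Amino for Methoxy on a Weak Benzylamide

This account rests on a few compounds, and the source may have more. Where it says the series, first, only, none or still open, it means among the compounds named here.

Three compounds share one core. Compound 1 `Cc1ccc2c(O)c(Cc3ccccc3)cnc2n1` reaches only a limit in an assay for binding affinity to adenosine receptor A1 (Bos taurus); a lower number here means a stronger inhibitor, a higher number a weaker inhibitor: compound 1 gives > 10000 nM, which is a limit of the assay and not a number. Compound 2 `Cc1ccc2c(O)c(C(=O)NC3CCC(C)CC3)cnc2n1` gives 6000 nM in this assay. Compound 3 `COc1ccc(CNC(=O)c2cnc3nc(C)ccc3c2O)cc1` likewise gives > 10000 nM in this assay, again a limit rather than a number. Compound 3 thus stands at the weak end of what is shown, at the limit of > 10000 nM in this assay, at which 2 of the 3 values shown sit. Compound 4 `Cc1ccc2c(O)c(C(=O)NCc3ccc(N)cc3)cnc2n1` differs from compound 3 by amino in place of methoxy on an aromatic carbon. Going by the values given here, no measured step covers such a change. In this assay the estimated step that the limit leaves unreadable from compound 3 to compound 4 is expected to be none beyond the scatter. Compound 4 is estimated at 15000 nM, with a range from 4000 nM to 60000 nM.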

Compound 4, inhibition constant: 2860 nM
For compound 4 the middle estimate is 5.2-fold (0.72 log units) above the measured one; measured number outside the range, below it.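

In this assay amino in place of methoxy gives an at least 3.4-fold lower number from compound 3 to compound 4 (0.54 log units; beyond the scatter) and so shows that this place on the benzylamide, para to a large group, responds to the group it carries. Compound 3 gives > 10000 nM in this assay, which is a limit and not a number, so the step is only a minimum, read from the shared ceiling: the limit of > 10000 nM in this assay, at which 2 of the 4 values shown sit.

As far as these compounds go, how a hydroxyl or a methylamino group would read at this place stays open. So does whether amino elsewhere on the aromatic ring would give a similar step.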